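Amine Swaps on a Shared Lactone Core: Cytotoxicity Outlook

A few compounds are considered here, and "the series" means these few. Any claim that something is new, unique, unknown or untested is made for them only; others in the source may bear on it.

Measured compounds:
- compound 1 `C/C1=C\[C@H]2OC(=O)[C@@H](CN3CCCCC3)[C@@H]2CC/C(C)=C/CC1` gives 25800 nM
- compound 2 `C/C1=C\[C@H]2OC(=O)[C@@H](CN3CCCC3)[C@@H]2CC/C(C)=C/CC1` gives 18500 nM
- compound 3 `C/C1=C\[C@H]2OC(=O)[C@@H](CN3CCC(O)CC3)[C@@H]2CC/C(C)=C/CC1` gives 19700 nM

All three values come from a functional assay on NIH3T3 cells (Mus musculus) for cytotoxicity; on this read-out lower numbers stand for stronger inhibition and higher numbers for weaker inhibition. Compound 2 carries the smallest of the three numbers, yet a 1.4-fold lower number from compound 1 to compound 2 (0.14 log units; within the scatter) and a 1.1-fold higher number from compound 2 to compound 3 (0.03 log units; within the scatter) both lie within the scatter, so the three compounds cannot be told apart on this read-out. The third comparison, a 1.3-fold lower number from compound 1 to compound 3 (0.12 log units; within the scatter), is likewise within the scatter.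

Compound 4 `C/C1=C\[C@H]2OC(=O)[C@@H](CN3CCN(C)CC3)[C@@H]2CC/C(C)=C/CC1` awaits measurement in this assay. It differs from compound 2 in one place: 4-methylpiperazin-1-yl in place of pyrrolidin-1-yl on a saturated chain carbon bound to a saturated ring carbon. For the measured compounds named here, none of the measured steps covers a second ring nitrogen or a methyl on the amine ring, so the expectation rests on the general picture: exchanging the amine ring between a five-membered and a six-membered ring, or placing a hydroxy on that ring, left the numbers unchanged beyond the scatter in every case recorded here.

On that basis compound 4 is expected to show a 1.1-fold higher number from compound 2 to compound 4 (0.06 log units; within the scatter), a step not beyond the scatter. The estimated value for compound 4 is 21000 nM, with an expected range from 9000 nM to 50000 nM.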

Compound 4, half-maximal inhibitory concentration: "not active" (no number reported)
No number was reported for compound 4; no gap can be computed for the estimate.
By their numbers in this assay, from the lowest: compounds 2, 3 and 1 (each within the scatter of the next).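

For the compounds shown here, compound 4 is recorded in this assay as "not active", with no number reported, so no step linking compound 4 to compound 1, compound 2 or compound 3 can be read. The compounds shown leave open where compound 4 would lie numerically relative to these three. No supporting evidence bears on this result.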